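From piperazin-1-yl to 1H-1,2,3-triazol-1-yl on the shared core

The compounds below may be only part of what the source reports. "The series", "measured", "known", "first", "only" and "open" are said of these compounds alone.

Going by the values given here, in a physicochemical assay for solubility (on this read-out higher numbers stand for higher solubility and lower numbers for lower solubility), compound 2 (`O=S(=O)(Nc1nccs1)c1ccc2c(c1)OCC[C@@H]2c1ccc(C(F)(F)F)cc1N1CCNCC1`) gives 288000 nM and holds the higher of the two numbers so far, while compound 1 (`Cn1nccc1-c1cc(C(F)(F)F)ccc1[C@H]1CCOc2cc(S(=O)(=O)Nc3nccs3)ccc21`) gives 83000 nM on the same read-out. Compound 3 (`O=S(=O)(Nc1nccs1)c1ccc2c(c1)OCC[C@@H]2c1ccc(C(F)(F)F)cc1-n1ccnn1`) is still unmeasured. It differs from compound 2 as follows: 1H-1,2,3-triazol-1-yl in place of piperazin-1-yl on an aromatic carbon on an aromatic carbon, ortho to a large group and meta to a trifluoromethyl group. Among the compounds with values here, one measured step bears on this change: a 3.5-fold higher number from compound 1 to compound 2 (0.54 log units; beyond the scatter) when piperazin-1-yl took the place of 1-methyl-1H-pyrazol-5-yl, a modest step beyond the scatter. Compound 3 gives up the same piperazin-1-yl for another aromatic group, so compound 1 is the closer guide. In this assay a modest fall is expected, an estimated 2.9-fold lower number from compound 2 to compound 3 (0.46 log units; beyond the scatter) that roughly reverses the measured step. Compound 3 is estimated at 100000 nM (expected range 40000 nM to 250000 nM).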

Compound 3, solubility: 171000 nM
The estimate for compound 3 lay 1.7-fold (0.23 log units) below the measured number; low and high end bracket the measured number.
By their numbers in this assay, from the lowest: compound 1; then compounds 3 and 2 (each within the scatter of the next).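

In this assay the exchange of piperazin-1-yl for 1H-1,2,3-triazol-1-yl, with a 1.7-fold lower number from compound 2 to compound 3 (0.23 log units; within the scatter), stays within the scatter, so at this place a non-aromatic six-membered ring and a five-membered aromatic ring cannot be told apart on this read-out. The two aromatic groups, by contrast, can be told apart, with a 2.1-fold higher number from compound 1 to compound 3 (0.31 log units; beyond the scatter) in this assay, so the earlier step from 1-methyl-1H-pyrazol-5-yl to piperazin-1-yl cannot be read as a general gap between aromatic and non-aromatic groups here.

Open, from the compounds shown here alone, is whether a morpholine, an open-chain amine or a carboxylic acid on this aromatic carbon would stand apart from these three compounds, and whether the methyl group of compound 1 has any part in its place among them. No measurement shown accounts for any of these differences.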